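The source may report more compounds than this note shows. Statements on the series, on what has been measured and on what is new or still open speak of the compounds shown alone.

Measured compounds, all in a functional assay on SMMC-7721 cells (Homo sapiens) for cytotoxicity, read by MTT assay, with a stated time of 48 h; on this read-out higher numbers stand for weaker inhibition and lower numbers for stronger inhibition; each value is a limit of the assay, not a number:
- compound 1 `C=CC(=C)[C@@H](O)C[C@H]1C(=C)CC[C@@H]2[C@]1(C)CCC[C@]2(C)C(=O)O`: compound 1 gives > 40000 nM
- compound 2 `C=C[C@@](C)(O)CC[C@H]1C(=C)CC[C@@H]2[C@]1(C)CCC[C@]2(C)C(=O)O`: compound 2 gives > 40000 nM
- compound 3 `C=C[C@]1(C)O[C@H]1C[C@H]1C(=C)CC[C@@H]2[C@]1(C)CCC[C@]2(C)C(=O)O`: compound 3 gives > 40000 nM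

Compound 3 stands only at a limit in this assay; the two other values shown are limits as well, so compound 3 cannot be placed relative to them. All three values sit at the limit of > 40000 nM in this assay, at which 3 of the 3 values shown sit, and the steps a step that the two limits leave unreadable from compound 1 to compound 2, a step that the two limits leave unreadable from compound 1 to compound 3 and a step that the two limits leave unreadable from compound 2 to compound 3 are therefore unreadable in both size and direction.

The next compound is compound 4 `C=CC(=C)[C@H](O)C[C@H]1C(=C)CC[C@@H]2[C@]1(C)CCC[C@]2(C)C(=O)O`, not yet measured in this assay. It differs from compound 3 by a group of 6 heavy atoms (5 carbon, 1 oxygen; no ring) in place of a group of 6 heavy atoms (5 carbon, 1 oxygen; one three-membered non-aromatic ring with 1 hetero atom), on a saturated chain carbon bound to a saturated ring carbon. The measured steps that bear on this change are those from compound 3 to the other two, but since every value involved is a limit they give no readable size. No step beyond the scatter is seen anywhere in the series; nothing supports a move away from the limit in either direction.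

The step from compound 3 to compound 4 is expected to be a step that the limit leaves unreadable from compound 3 to compound 4. Compound 4 is estimated at 60000 nM, with a range of 30000 nM to 200000 nM, most likely reported again as a limit.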

Compound 4, half-maximal inhibitory concentration: > 40000 nM
Compound 4 was reported as a limit; the forecaster's own chance of this, stated with the estimate: 85%; the middle value does not contradict the limit.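

In this assay compound 4 gives > 40000 nM, a limit of the assay. Among the compounds shown here, no step among compound 1, compound 2, compound 3 and compound 4 can be read in size or direction: the limit of > 40000 nM in this assay, at which 4 of the 4 values shown sit. The compounds shown leave open whether configuration at the saturated chain carbon has any effect on this read-out: the fact that compounds 1 and 4 differ only in the configuration as drawn.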